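The source may report more compounds than this note shows. Statements on the series, on what has been measured and on what is new or still open speak of the compounds shown alone.

Measured in a functional assay on TSGH cells (Homo sapiens) for inhibition, with a stated time of 72 h; a lower number here means a stronger inhibitor, a higher number a weaker inhibitor:
Compound 1 `COc1cc(C(=O)c2ccc3c(ccn3C)c2)cc(OC)c1OC`: 13.4 nM
Compound 2 `CCCn1ccc2cc(C(=O)c3cc(OC)c(OC)c(OC)c3)ccc21`: 1500 nM
Compound 3 `COc1cc(C(=O)c2ccc3c(ccn3CO)c2)cc(OC)c1OC`: 43 nM

Compound 3 holds the middle place of the three, the second highest number, and the closest to it is compound 1. Compound 4 `COc1cc(C(=O)c2ccc3c(ccn3CCC(=O)O)c2)cc(OC)c1OC` differs from compound 3 in one place: carboxymethyl in place of hydroxy on a saturated chain carbon bound to an aromatic nitrogen. That is carboxymethyl in place of hydroxy on a saturated chain carbon bound to an aromatic nitrogen.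

Three measured steps changed this same carbon. Hydroxy cost little, a 3.2-fold higher number from compound 1 to compound 3 (0.51 log units; beyond the scatter), whereas ethyl cost much more, a 110-fold higher number from compound 1 to compound 2 (2.05 log units; beyond the scatter). Removing ethyl in favour of hydroxy regained most of that loss, a 35-fold lower number from compound 2 to compound 3 (1.54 log units; beyond the scatter). Going by the values given here, no measured compound carries carboxymethyl, so the size stays uncertain, but a large rise is expected: a 16-fold higher number from compound 3 to compound 4 (1.21 log units; beyond the scatter). For compound 4 the estimated value is 700 nM, with an expected range of 120 nM to 4000 nM.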

Compound 4, half-maximal inhibitory concentration: > 10000 nM
Compound 4 gave a limit, no number; the forecaster's own chance of this, stated with the estimate: 10%; middle value at least 14-fold (1.15 log units) away from the limit.
By their numbers in this assay, from the lowest: compound 1; then compound 3; then compound 2. At a limit, above all of these: compound 4.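

On this carbon, the 2-carboxyethyl chain costs far more than hydroxymethyl (an at least 230-fold higher number from compound 3 to compound 4 (2.36 log units; beyond the scatter)) and far more than the methyl of compound 1 (an at least 740-fold higher number from compound 1 to compound 4 (2.87 log units; beyond the scatter)). The loss is not a matter of the chain alone: carboxy in place of methyl, two bonds along the chain from the aromatic nitrogen, weakens the compound further (an at least 6.6-fold higher number from compound 2 to compound 4 (0.82 log units; beyond the scatter)). Compound 4 gives only a limit, so these steps are minimum sizes: the limit of > 10000 nM in this assay, at which 1 of the 4 values shown sits.

Still open, as far as these compounds go, is whether an amine or a methyl ester at the end of this chain would be tolerated better than the carboxylic acid. A shorter chain ending in a carboxylic acid also remains untested among the compounds shown.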